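A few compounds are considered here, and "the series" means these few. Any claim that something is new, unique, unknown or untested is made for them only; others in the source may bear on it.

Three compounds with a shared core have been examined in an ADME assay on MT4 cells (Homo sapiens) for cytotoxicity, read by MTT assay; on this read-out lower numbers stand for higher toxicity in this test and higher numbers for lower toxicity in this test. Compound 1 `Cc1cc(C#N)cc(C)c1Oc1ccnc(Nc2ccc(CN3CCCN(S(=O)(=O)C4CC4)CC3)cc2)n1` is recorded as "not active" (no number reported), with no number reported. Compound 2 `Cc1cc(C#N)cc(C)c1Oc1ccnc(Nc2ccc(CN3CCCN(S(C)(=O)=O)CC3)cc2)n1` gives 7850 nM. Compound 3 `CCS(=O)(=O)N1CCN(Cc2ccc(Nc3nccc(Oc4c(C)cc(/C=C/C#N)cc4C)n3)cc2)CC1` gives 4600 nM, and this number and that of compound 2 lie within the usual scatter of each other, so nothing can be said about an order between them. Compound 4 `Cc1cc(/C=C/C#N)cc(C)c1Oc1ccnc(Nc2ccc(CN3CCN(S(=O)(=O)N(C)C)CC3)cc2)n1` differs from compound 3 only in that (dimethylamino in place of ethyl on a sulfonyl sulfur). Within the data shown here, no step of this kind has been measured here, so the expectation for compound 4 rests on compound 3 alone, and a step of no change at the digits printed from compound 3 to compound 4 (within the scatter) is expected, no further than the scatter in either direction. Compound 4 is therefore estimated at 4600 nM, with a range from 2000 nM to 11000 nM.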

Compound 4, half-maximal cytotoxic concentration: 3070 nM
Compound 4: middle estimate off by 1.5-fold (0.18 log units), on the high side; the measured number falls inside the stated range.
By their numbers in this assay, from the lowest: compounds 4, 3 and 2 (each within the scatter of the next, the first and the last beyond it).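

Among these compounds, the step at the sulfonyl sulfur gives the first direct comparison in this assay: dimethylamino in place of ethyl goes with a 1.5-fold lower number from compound 3 to compound 4 (0.18 log units; within the scatter). On this read-out, the two groups therefore cannot be told apart at this position on the shared core. Nothing available here bears on why they read alike.

The compounds shown leave open whether a phenyl group or a longer chain such as butyl on the same sulfur would move the number beyond the scatter.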